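The compounds below may be only part of what the source reports. "The series", "measured", "known", "first", "only" and "open" are said of these compounds alone.

In a physicochemical assay for lipophilicity, at pH 7.4 (a lower number here means a more polar compound, a higher number a more lipophilic compound), compound 1 (`Cc1cc(C(=O)Nc2ccc(F)cc2)nn1Cc1cc(Cl)ccc1OCc1ccccc1`) gives 3. Compound 2 (`CC(=O)Nc1cc(C)n(Cc2cc(Cl)ccc2OCc2ccccc2)n1`) stands at > 3.7, which is a limit of the assay and not a number. Compared with compound 2, compound 3 (`Cc1cc(NC(=O)CC(C)(C)C)nn1Cc1cc(Cl)ccc1OCc1ccccc1`) carries tert-butyl in place of hydrogen on a saturated chain carbon bound to a carbonyl carbon. Within the data shown here, the only measured step is a number at least 0.70 log units higher from compound 1 to compound 2 (beyond the scatter), and it swaps a whole group, so it bears only loosely on this change. An upward move is expected, resting mainly on the added carbons, and the estimated step is a step that the limit leaves unreadable from compound 2 to compound 3. For compound 3 the estimated value is 4.3, with a range of 3.7 to 5.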

Compound 3, distribution coefficient: > 3.7
Compound 3: only a limit was reported; the forecaster's own chance of this, stated with the estimate: 75%; the middle value is on the limit's open side.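

In this assay compound 3 gives > 3.7, a limit of the assay and not a number. Putting (neopentylcarbonyl)amino in place of (4-fluorophenyl)carbamoyl on the aromatic carbon gives a number at least 0.70 log units higher from compound 1 to compound 3 (beyond the scatter), so a second replacement of that group now ends at the same limit. The effect of adding tert-butyl on the saturated chain carbon bound to a carbonyl carbon cannot be read, because both compounds end at the limit: the limit of > 3.7 in this assay, at which 2 of the 3 values shown sit.

Still open, going by these compounds, is whether a carboxylic acid or an amine in place of tert-butyl would give a readable number in this assay.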